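Pyrimidinyl for thiadiazolyl at the thioether sulfur

The source may report more compounds than this note shows. Statements on the series, on what has been measured and on what is new or still open speak of the compounds shown alone.

Working notes on the hydrazone thioether series. In an ADME assay on NIH3T3 cells (Mus musculus) for cytotoxicity, read by MTT assay, with a stated time of 24 h (on this read-out lower numbers stand for stronger inhibition and higher numbers for weaker inhibition), compound 1 `Cc1nnc(SCC(=O)N/N=c2/scc(-c3ccccc3)n2-c2ccccc2)s1` gives 197 ug/mL. Compound 2 `Cc1nnc(SCC(=O)N/N=c2/scc(-c3ccc(Cl)cc3)n2-c2ccccc2)s1`, which carries chloro in place of hydrogen on an aromatic carbon, gives 253 ug/mL in this assay, the higher of the two numbers reported, though the step of a 1.3-fold higher number from compound 1 to compound 2 (0.11 log units; within the scatter) separates it from nothing. Compound 3 `Cc1nnc(SCC(=O)N/N=c2/scc(-c3ccc(C#N)cc3)n2-c2ccccc2)s1`, with cyano in place of hydrogen on an aromatic carbon, is reported in this assay only as a limit, < 3.9 ug/mL. The steps of an at least 50-fold lower number from compound 1 to compound 3 (1.70 log units; beyond the scatter) and an at least 64-fold lower number from compound 2 to compound 3 (1.81 log units; beyond the scatter) are both large and both rest on (the limit of < 3.9 ug/mL in this assay, at which 1 of the 3 values shown sits).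

Compound 4 `O=C(CSc1ncccn1)N/N=c1/scc(-c2ccc(Cl)cc2)n1-c1ccccc1` keeps the chloro of compound 2 and differs from it at the sulfur: pyrimidin-2-yl in place of 5-methyl-1,3,4-thiadiazol-2-yl on a sulfur. Within the data shown here, none of the measured steps touches this position; all three alter a substituent on an aromatic carbon, and only the cyano one moved far while the chloro one stayed within the scatter. With no comparison at the sulfur, the expected step of a 1.3-fold lower number from compound 2 to compound 4 (0.10 log units; within the scatter) in this assay is set at none beyond the scatter, with a wide range to cover the untested position. Compound 4 is therefore estimated at 200 ug/mL in this assay, between 60 ug/mL and 450 ug/mL.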

Compound 4, half-maximal inhibitory concentration: 397 ug/mL
The estimate for compound 4 lay 2.0-fold (0.30 log units) below the measured number; measured number inside the range.
By their numbers in this assay, from the lowest: compounds 1, 2 and 4 (each within the scatter of the next). At a limit, below all of these: compound 3.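

Among these compounds, the thioether sulfur is tested here for the first time: in this assay, the step of a 1.6-fold higher number from compound 2 to compound 4 (0.20 log units; within the scatter) shows that, with the chloro kept, pyrimidin-2-yl can take the place of 5-methyl-1,3,4-thiadiazol-2-yl on a sulfur without a change beyond the scatter. Among the compounds shown here, at this place, therefore, a six-membered aromatic ring with 2 hetero atoms and a five-membered aromatic ring with 3 hetero atoms are not told apart by this read-out, so the only large steps remain those that introduce the cyano group on an aromatic carbon. Nothing shown here gives a reason for this result.

From the compounds shown here alone, it remains open whether the pyrimidin-2-yl group would give the same picture with cyano in place of chloro, the change that took compound 3 to a limit of the assay. Going by these compounds, it is also open how this place would respond to a group of a different kind on the sulfur, such as a plain phenyl ring, a longer chain ending in an amine or a carboxylic acid.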